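A Single Group Exchanged on Compound 2

The compounds below may be only part of what the source reports. "The series", "measured", "known", "first", "only" and "open" are said of these compounds alone.

In a physicochemical assay for solubility, at pH 7.4 (on this read-out higher numbers stand for higher solubility and lower numbers for lower solubility), compound 1 (`CNC1(C)CN(c2cc3c(cc2F)c(=O)c(C(=O)O)cn3C2CC2)C1`) gives 0.7 ug/mL, compound 2 (`CNC1(C)CN(c2c(F)cc3c(=O)c(C(=O)O)cn(C4CC4)c3c2F)C1`) gives 0.5 ug/mL and compound 3 (`C[C@H]1N(c2cc3c(cc2F)c(=O)c(C(=O)O)cn3C2CC2)C[C@]1(C)N`) gives 1.3 ug/mL. Compound 2 thus stands with compound 1 at the low end of these numbers, the two lying within the scatter of each other, while compound 3 stands clear of compound 2.

Compound 4 (`C[C@H]1[C@@H](N)CN1c1c(F)cc2c(=O)c(C(=O)O)cn(C3CC3)c2c1F`) has not yet been measured. It differs from compound 2 in one place: a group of 6 heavy atoms (4 carbon, 2 nitrogen; one four-membered non-aromatic ring with 1 hetero atom) in place of a group of 7 heavy atoms (5 carbon, 2 nitrogen; one four-membered non-aromatic ring with 1 hetero atom), on an aromatic carbon. The 3-methyl-3-(methylamino)azetidin-1-yl group leaves an aromatic carbon ortho to two fluoro groups, and a group with 2 defined stereocentres enters there.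

Within the data shown here, two measured steps bear on this. One is a 1.4-fold lower number from compound 1 to compound 2 (0.15 log units; within the scatter), with fluoro in place of hydrogen on an aromatic carbon. The other is a 1.9-fold higher number from compound 1 to compound 3 (0.27 log units; within the scatter), with one group exchanged for another of the same heavy-atom count. Among the measured compounds shown here, no measured compound carries the group entering compound 4, so the second step is only a loose guide. For the measured compounds named here, with compound 3 at 1.3 ug/mL as the one upward guide, a small rise is expected in this assay, no larger than the scatter. The estimated change is a 1.6-fold higher number from compound 2 to compound 4 (0.20 log units; within the scatter). For compound 4 the estimated value is 0.8 ug/mL, with an expected range from 0.3 ug/mL to 2 ug/mL.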

Compound 4, solubility: 23.6 ug/mL
For compound 4 the middle estimate is 30-fold (1.47 log units) below the measured one; the whole stated range lies below it.
By their numbers in this assay, from the lowest: compounds 2, 1 and 3 (each within the scatter of the next, the first and the last beyond it); then compound 4.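

Exchanging the 3-methyl-3-(methylamino)azetidin-1-yl group on this aromatic carbon, ortho to two fluoro groups, gives in this assay a 47-fold higher number from compound 2 to compound 4 (1.67 log units; beyond the scatter), the only step shown that is marked large. Among these compounds, this sets the position apart from the earlier steps, a 1.4-fold lower number from compound 1 to compound 2 (0.15 log units; within the scatter) and a 1.9-fold higher number from compound 1 to compound 3 (0.27 log units; within the scatter), which both stayed within the scatter, so a change of group here can move this read-out far beyond it. The change is also small by the counts: each group has a four-membered non-aromatic ring with 1 hetero atom, neither carries a net charge, and their hydrogen-bond donors and acceptors match, leaving 6 heavy atoms in place of 7 and the 2 defined stereocentres of the entering group as the counted differences, and nothing at hand accounts for the size of the step.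

The compounds shown do not separate the drop in heavy atoms from the defined stereocentres, nor do they tell whether the entering group would give a step of this size on the core of compound 1, which has a hydrogen in place of one fluoro group. From the compounds shown here alone, how a larger amine at this position, such as a 3-aminopyrrolidin-1-yl group, would read also remains open.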